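The source may report more compounds than this note shows. Statements on the series, on what has been measured and on what is new or still open speak of the compounds shown alone.

Values in a functional assay (microsomes, liver) with Rattus norvegicus as the target; on this read-out lower numbers stand for stronger inhibition and higher numbers for weaker inhibition:
- compound 1 `Cc1c(C)c2c(c(C)c1N)CC(C)(C)O2`: 760 nM
- compound 2 `Cc1c(C)c2c(c(C)c1N)C(c1ccc(F)cc1)C(C)(C)O2`: 280 nM

Compound 2 has the lower number of the two. Compound 3 `Cc1c(C)c2c(c(C)c1N)C(C(C)C)C(C)(C)O2` departs from it with isopropyl in place of 4-fluorophenyl on a saturated ring carbon. Among the compounds with values here, only one measured step bears on this change: a 2.7-fold lower number from compound 1 to compound 2 (0.43 log units; beyond the scatter), a modest step that put 4-fluorophenyl in place of hydrogen at that carbon. Within the data shown here, no isopropyl compound has been measured, so part of that gain is expected to be lost, giving a modest rise in this assay. The expected change is a 1.4-fold higher number from compound 2 to compound 3 (0.15 log units; within the scatter). For compound 3 the estimated value is 400 nM, with a range of 170 nM to 950 nM.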

Compound 3, half-maximal inhibitory concentration: 290 nM
Beside the measured number, compound 3's estimate is 1.4-fold (0.14 log units) above it; the range from low to high includes it.
By their numbers in this assay, from the lowest: compounds 2 and 3 (each within the scatter of the next); then compound 1.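

In this assay, the step with isopropyl in place of 4-fluorophenyl on the saturated ring carbon is a 1.0-fold higher number from compound 2 to compound 3 (0.02 log units; within the scatter) and stays within the scatter, so among these compounds an aromatic ring at this carbon is not needed. With isopropyl in place of hydrogen, the step is a 2.6-fold lower number from compound 1 to compound 3 (0.42 log units; beyond the scatter) and lies beyond the scatter, so a group without a ring also gives a step of this kind, as 4-fluorophenyl did (a 2.7-fold lower number from compound 1 to compound 2 (0.43 log units; beyond the scatter)). Nothing available explains why the two groups read alike.

The compounds shown leave open whether a carboxylic acid or an amine at this carbon would keep the number of compound 3 (290 nM). They also leave open whether a longer chain there would do so.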